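The source may hold more compounds than are shown below. What is called first, only, known or untested is meant among the compounds shown, and "the series" means these compounds.

Of the compounds shown here, three sharing one core have been tested in a functional assay on DU-145 cells (Homo sapiens) for inhibition, read by trypan blue exclusion, with a stated time of 72 h (a higher number here means a weaker inhibitor, a lower number a stronger inhibitor), so far. Compound 1 (`Cn1c(=O)c(S(=O)(=O)c2ccc(F)cc2)cc2cnc(Nc3ccc4occc4c3)nc21`) reads 5000 nM there, and compound 2 (`Cn1c(=O)c(S(=O)(=O)c2ccc(F)cc2)cc2cnc(Nc3ccc4cc[nH]c4c3)nc21`) reads 10000 nM there. Compound 3 (`Cn1c(=O)c(S(=O)(=O)c2ccc(F)cc2)cc2cnc(Nc3ccc4[nH]ccc4c3)nc21`) reads 300 nM there. The steps around compound 2 show where it stands: there is a 2.0-fold higher number from compound 1 to compound 2 (0.30 log units; within the scatter) on one side and a 33-fold lower number from compound 2 to compound 3 (1.52 log units; beyond the scatter) on the other, so it lies at the weak end of the three, together with compound 1.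

Compound 4 (`Cc1ccc(S(=O)(=O)c2cc3cnc(Nc4ccc5cc[nH]c5c4)nc3n(C)c2=O)cc1`) differs from compound 2 in one place: methyl in place of fluoro on an aromatic carbon, which turns 4-fluorophenyl into 4-methylphenyl. Within the data shown here, no measured step makes this kind of change. All three alter only the group on the nitrogen, and their sizes run from within the scatter to large, so they give little guidance here. No step beyond the scatter is therefore expected in this assay in either direction. The expected outcome is a 1.3-fold lower number from compound 2 to compound 4 (0.10 log units; within the scatter) as an estimate. Compound 4 is therefore estimated at 8000 nM (range 3000 nM to 20000 nM).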

Compound 4, half-maximal inhibitory concentration: 15000 nM
Beside the measured number, compound 4's estimate is 1.9-fold (0.27 log units) below it; measured number inside the range.
By their numbers in this assay, from the lowest: compound 3; then compounds 1, 2 and 4 (each within the scatter of the next, the first and the last beyond it).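

Among these compounds, compound 4 gives the first reading on the 4-fluorophenyl ring, since the earlier steps changed only the group on the nitrogen, and in this assay putting methyl in place of fluoro gives a 1.5-fold higher number from compound 2 to compound 4 (0.18 log units; within the scatter). Compound 2 and compound 4 therefore cannot be told apart, so on this background the exchange of one small group for another at this ring position has no measurable effect on the number. No measurement shown here bears on why this is so.

As far as these compounds go, it remains open whether the same exchange would also leave the number in place on the 1H-indol-5-yl group of compound 3, at 300 nM, where any change would be easier to see against a much lower number. Also open, from the compounds shown here alone, is how a methoxy group, an amine or a carboxylic acid would read at this ring position.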